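Notes on the step from compound 2 to compound 3

The source may hold more compounds than are shown below. What is called first, only, known or untested is meant among the compounds shown, and "the series" means these compounds.

Measured so far in a functional assay on MCF7 cells (Homo sapiens) for inhibition, read by MTT assay, with a stated time of 3 days (a higher number here means a weaker inhibitor, a lower number a stronger inhibitor), as follows
- compound 1 `COc1cc(-c2nc3ccccc3s2)ccc1OCC(=O)NNC(O)CN(C)CC(=O)O` gives 1960 nM
- compound 2 `CC[C@H](C)[C@@H](NCC(=O)NNC(=O)COc1ccc(-c2nc3ccccc3s2)cc1OC)C(=O)O` gives 1790 nM

Compound 2 at 1790 nM stands level with compound 1, the only other measured point, and the two values lie within the scatter of each other. Compound 3 `COc1cc(-c2nc3ccccc3s2)ccc1OCC(=O)NNC(=O)CN[C@@H](CS(=O)(=O)O)C(=O)O` carries 1-carboxy-2-sulfoethyl in place of 1-carboxy-2-methylbutyl on an amine nitrogen. Going by the values given here, no measured step covers this change, so the expectation rests on little. Compound 1 at 1960 nM and compound 2 at 1790 nM show no spread to build on, so no shift beyond the scatter is expected in this assay, and a wide range is kept. The estimated step of a 1.1-fold higher number from compound 2 to compound 3 (0.05 log units; within the scatter) is small. The expected value for compound 3 is 2000 nM (estimated range 800 nM to 5000 nM).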

Compound 3, half-maximal inhibitory concentration: 1870 nM
Estimate against measurement, compound 3: 1.1-fold (0.03 log units) above; low and high end bracket the measured number.
By their numbers in this assay, from the lowest: compounds 2, 3 and 1 (each within the scatter of the next).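

In this assay, going by these compounds alone, the swap of 1-carboxy-2-methylbutyl for 1-carboxy-2-sulfoethyl on an amine nitrogen gives the first single-place comparison: a 1.0-fold higher number from compound 2 to compound 3 (0.02 log units; within the scatter), within the scatter. At this position, the two groups therefore read alike in this assay, although they differ in their elements, hydrogen-bond donors and acceptors, and defined stereocentres. No supporting measurement accounts for this result.

As far as these compounds go, whether the same reading would hold with an amine at the end of this side chain, a phenyl ring on it or a longer chain stays open. The compounds shown also leave open what the carboxylic acid shared by both groups contributes, since no comparison here separates it from the rest of the side chain.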